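The source may report more compounds than this note shows. Statements on the series, on what has been measured and on what is new or still open speak of the compounds shown alone.

Compounds measured so far:
compound 1 `CCOC(=O)c1cc(=O)c2cc(CSC(=S)N(C)c3ccccc3)ccc2o1` — in a functional assay on MDA-MB-435S cells (Homo sapiens) for antiproliferative activity, read by MTT assay, with a stated time of 72 h (a lower number here means a stronger inhibitor, a higher number a weaker inhibitor), compound 1 gives 13500 nM
compound 2 `CC(C)N(C(=S)SCc1cc(=O)c2ccc(Cl)cc2o1)C(C)C` — compound 2 reaches only a limit, > 25000 nM

Compound 1 thus carries the only numerical result in this assay, the other value being a limit (the limit of > 25000 nM in this assay, at which 1 of the 2 values shown sits). Compound 3 `CCOC(=O)c1cc(=O)c2cc(CSC(=S)N3CCCCC3)ccc2o1` differs from compound 1 by piperidin-1-yl in place of methyl(phenyl)amino on a thiocarbonyl carbon. Going by the values given here, with no measured pair of this kind to lean on, the step from compound 1 to compound 3 in this assay is expected to stay within the usual scatter, with no clear direction. Compound 3 is therefore estimated at 15000 nM, in a range from 6000 nM to 40000 nM. That expectation corresponds to a step of a 1.1-fold higher number from compound 1 to compound 3 (0.05 log units; within the scatter).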

Compound 3, half-maximal inhibitory concentration: 2900 nM
Compound 3: middle estimate off by 5.2-fold (0.71 log units), on the high side; measured number outside the range, below it.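

In this assay, the group on the thiocarbonyl carbon proves to matter: piperidin-1-yl in place of methyl(phenyl)amino gives a 4.7-fold lower number from compound 1 to compound 3 (0.67 log units; beyond the scatter). In this single pair, with the rest of the molecule unchanged, the non-aromatic ring gives the stronger inhibitor. Nothing shown here accounts for this step. On these data alone, it remains open whether morpholin-4-yl or an open-chain dimethylamino group on a thiocarbonyl carbon would give a similar number. As far as these compounds go, it also remains open whether piperidin-1-yl would give a step of this size on another core.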